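The compounds below may be only part of what the source reports. "The series", "measured", "known", "first", "only" and "open" are said of these compounds alone.

Measured so far in a functional assay on HT-29 cells (Homo sapiens) for cytotoxicity, read by sulforhodamine B assay, with a stated time of 48 h; on this read-out lower numbers stand for stronger inhibition of growth and higher numbers for weaker inhibition of growth:
- compound 1 `COc1ccc2[nH]cc(C(=O)c3cc(OC)c(OC)c(OC)c3N)c2c1`: 950 nM
- compound 2 `COc1cc(C(=O)c2c[nH]c3c(OC)cccc23)c(N)c(OC)c1OC`: 48600 nM

Compound 1 holds the lowest of the two numbers in this assay; compound 2 gives a number well above it, and the gap between the two is beyond the scatter. Going by the values given here, no pair that differs in only one place has been measured, so no single-change step is known.

Compound 3 `COc1cc2[nH]cc(C(=O)c3cc(OC)c(OC)c(OC)c3N)c2cc1OC` differs from compound 1 by methoxy in place of hydrogen on an aromatic carbon, on an aromatic carbon of the six-membered carbon ring of the fused system, ortho to the methoxy group already present. Among the compounds with values here, with no comparable step on record, the expectation is a small move in this assay, if any, most likely toward a somewhat higher number, yet within reach of the scatter. The step expected from compound 1 to compound 3 is a 1.6-fold higher number from compound 1 to compound 3 (0.20 log units; within the scatter). Compound 3 is estimated at 1500 nM, with a range from 300 nM to 8000 nM.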

Compound 3, concentration for 50% growth inhibition: 24400 nM
Beside the measured number, compound 3's estimate is 16-fold (1.21 log units) below it; the measured number lies above the stated range.
By their numbers in this assay, from the lowest: compound 1; then compounds 3 and 2 (each within the scatter of the next).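

In this assay, going by these compounds alone, methoxy in place of hydrogen on an aromatic carbon, ortho to a methoxy group, gives a 26-fold higher number from compound 1 to compound 3 (1.41 log units; beyond the scatter) and so provides the first single-change step. The step is large for a change of 2 heavy atoms, so the lower number of compound 1 does not survive added methoxy at this place on the six-membered aromatic ring. Nothing at hand bears on why the number rises here.

Going by these compounds, whether the step belongs to methoxy itself remains open: fluorine, a hydroxyl or an ethoxy group at this place would show whether any group there raises the number or only some do. Also open, on these data alone, is whether the step depends on the methoxy group already present, which a compound carrying the new methoxy alone would settle.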